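The source may report more compounds than this note shows. Statements on the series, on what has been measured and on what is new or still open speak of the compounds shown alone.

Compound 1 `Cc1nnc(-c2cccc(-c3ccc(C(=O)N(Cc4cccc(OCCCCCC(=O)O)c4)C(C)C)cc3)c2)o1` is the point from which this account sets out. In an ADME assay on BJ cells (Homo sapiens) for cytotoxicity, read by CellTiter-Glo and resazurin assay, with a stated time of 72 h (on this read-out lower numbers stand for an effect already at smaller amounts and higher numbers for an effect only at larger amounts of compound), compound 1 gives only a limit of the assay, > 26000 nM, and no number. Compound 2 `CC(C)N(Cc1cccc(OCCCCCC(=O)O)c1)C(=O)c1ccc(-c2c[nH]c3ccccc23)cc1` also reaches only a limit in this assay, > 26000 nM. Compound 3 `COc1cc(F)cc(-c2ccc(C(=O)N(Cc3cccc(OCCCCCC(=O)O)c3)C(C)C)cc2)c1` gives a limit in this assay as well, > 26000 nM. All three measured values therefore sit at the same place, (the limit of > 26000 nM in this assay, at which 3 of the 3 values shown sit), and none of the three steps among them can be read: from compound 1 to compound 2 the record shows a step that the two limits leave unreadable from compound 1 to compound 2, from compound 1 to compound 3 it shows a step that the two limits leave unreadable from compound 1 to compound 3, and from compound 2 to compound 3 it shows a step that the two limits leave unreadable from compound 2 to compound 3. Compound 4 `CC(C)N(Cc1cccc(OCCCCCC(=O)O)c1)C(=O)c1ccc(-c2cccc(S(C)(=O)=O)c2)cc1` has not yet been measured. It differs from compound 1 in a single place: methylsulfonyl in place of 5-methyl-1,3,4-oxadiazol-2-yl on an aromatic carbon. Since every measured step is unreadable, there is no evidence of any size or direction to carry over. Because all three shown values sit at the limit (the limit of > 26000 nM in this assay, at which 3 of the 3 values shown sit), compound 4 is expected to behave the same way, and the step from compound 1 to compound 4 is estimated as a number no higher from compound 1 to compound 4 (the limit leaves the size open). For compound 4 the estimate is 26000 nM, within a range from 13000 nM to 52000 nM, most probably reported again only as a limit.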

Compound 4, half-maximal effective concentration: > 26000 nM
Compound 4 ended at the assay's limit; the forecaster's own chance of this, stated with the estimate: 85%; the middle value lies on the limit itself.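

Compound 4 joins compound 1, compound 2 and compound 3 at the same limit, and none of the steps from those three compounds to compound 4 can be read: the limit of > 26000 nM in this assay, at which 4 of the 4 values shown sit. The compounds shown leave open at what concentration any of them would have an effect in this assay and whether the exchanged groups make any difference there.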